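Replacing the 3,5-difluorophenyl group of compound 2

The source may hold more compounds than are shown below. What is called first, only, known or untested is meant among the compounds shown, and "the series" means these compounds.

Measured so far in a physicochemical assay for solubility; a higher number here means a more soluble compound, a lower number a less soluble compound:
- compound 1 `CS(=O)(=O)c1ccc(-n2nc(C(F)F)c(C#N)c2-c2ccccc2)nc1`: "not determined" (no result reported)
- compound 2 `CS(=O)(=O)c1ccc(-n2nc(C(F)F)c(C#N)c2-c2cc(F)cc(F)c2)nc1`: 50 ug/mL
- compound 3 `C[C@@H]1CN(c2cc(C(F)(F)F)nn2-c2ccc(S(C)(=O)=O)cn2)[C@H](C)CO1`: 100 ug/mL

Only compound 2 and compound 3 have numbers, and these two lie within the usual scatter of each other. Compound 1 has no result to compare.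

Compound 4 `C[C@@H]1CN(c2c(C#N)c(C(F)F)nn2-c2ccc(S(C)(=O)=O)cn2)[C@H](C)CO1` is still unmeasured. Its structure departs from compound 2 as follows: a group of 8 heavy atoms (6 carbon, 1 nitrogen, 1 oxygen; one six-membered non-aromatic ring with 2 hetero atoms) in place of a group of 8 heavy atoms (6 carbon, 2 fluorine; one six-membered aromatic ring of carbon only), on an aromatic carbon. The entering group also occurs in compound 3, which gives 100 ug/mL but has no nitrile and carries trifluoromethyl instead of difluoromethyl. A small rise in this assay is therefore expected, and it may not exceed the scatter. The estimated step is a 1.6-fold higher number from compound 2 to compound 4 (0.20 log units; within the scatter). For compound 4 the expected value is 80 ug/mL, with an estimated range from 30 ug/mL to 200 ug/mL.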

Compound 4, solubility: > 200 ug/mL
Compound 4: only a limit was reported; the forecaster's own chance of this, stated with the estimate: 15%; middle value at least 2.5-fold (0.39 log units) from the limit.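

With the nitrile and difluoromethyl groups kept in place, exchanging only the 3,5-difluorophenyl group on this aromatic carbon gives an at least 4.0-fold higher number from compound 2 to compound 4 (0.60 log units; beyond the scatter) in this assay. Compounds 2 and 3 differ in more than one place, so they could not isolate this position. As far as these compounds go, for compound 4, the reported > 200 ug/mL is a limit and not a number, so the full size of the step stays unknown.

The compounds shown cannot separate the contributions of the entering ring's hetero atoms and its two defined stereocentres. From the compounds shown here alone, how a simple open-chain amine or a carboxylic acid would compare at this carbon also remains open.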